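A few compounds are considered here, and "the series" means these few. Any claim that something is new, unique, unknown or untested is made for them only; others in the source may bear on it.

Compound 1 `CCC(C)C(=O)Nc1c(C(O)(C(F)(F)F)C(F)(F)F)ccc2ccccc12` gives 177000 nM in an assay on LtK cells with ATP-sensitive inward rectifier potassium channel 11 (Homo sapiens) as the target (on this read-out lower numbers stand for an effect already at smaller amounts and higher numbers for an effect only at larger amounts of compound), while compound 2 `COCC(=O)Nc1c(C(O)(C(F)(F)F)C(F)(F)F)ccc2ccccc12` gives 213 nM, so compound 2 stands with the lowest number of the two measured. Within the data shown here, the single measured step, an 830-fold lower number from compound 1 to compound 2 (2.92 log units; beyond the scatter), shows that the group on the carbonyl carbon matters greatly. Compound 3 `O=C(Nc1c(C(O)(C(F)(F)F)C(F)(F)F)ccc2ccccc12)c1cccc(Cl)c1` differs from compound 2 by 3-chlorophenyl in place of methoxymethyl on a carbonyl carbon. Among the measured compounds shown here, only that one step bears on this change; it shows the position is sensitive but not which way an aromatic group will move the number. A moderate shift to a higher number is expected, a 9.4-fold higher number from compound 2 to compound 3 (0.97 log units; beyond the scatter). Compound 3 is therefore estimated at 2000 nM, within 200 nM to 20000 nM.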

Compound 3, half-maximal effective concentration: 98 nM
Beside the measured number, compound 3's estimate is 20-fold (1.31 log units) above it, and the stated range ends above it.
By their numbers in this assay, from the lowest: compound 3; then compound 2; then compound 1.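

In this assay, the carbonyl carbon also accepts an aromatic ring: 3-chlorophenyl gives a 2.2-fold lower number from compound 2 to compound 3 (0.34 log units; beyond the scatter) and also a 1800-fold lower number from compound 1 to compound 3 (3.26 log units; beyond the scatter). Of the three groups, then, a ring with chlorine gives the lowest number and sec-butyl the highest, so a low number does not depend on keeping the methoxymethyl group. Nothing measured here explains why these groups differ. On these data alone, it remains open whether the chlorine of 3-chlorophenyl contributes, which plain phenyl could test. Also open, as far as these compounds go, is how an amine or a longer chain would behave at this place.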